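From Nitrile to Tetrazole in a Leukotriene Receptor Series

The source may report more compounds than this note shows. Statements on the series, on what has been measured and on what is new or still open speak of the compounds shown alone.

Of the compounds shown here, two have so far been measured in an assay on isolated protein for inhibition of leukotriene B4 receptor 1 (Homo sapiens), tested at 10 uM; on this read-out lower numbers stand for less inhibition and higher numbers for more inhibition at the one concentration tested (going by the name of the read-out). Compound 1, `CC(=O)c1cc(CC2CO2)c(OCCCCC#N)cc1O`, gives 62% in this assay. Compound 2, `CCc1cc(C(C)=O)c(O)cc1OCCCC(C)(C)C#N`, gives 85% in this assay, the higher of the two numbers, and its gap to compound 1 lies beyond the usual scatter of repeated measurements. Compound 3, `CCc1cc(C(C)=O)c(O)cc1OCCCCc1nnn[nH]1`, is yet to be measured. It differs from compound 2 in a single place: (1H-tetrazol-5-yl)methyl in place of 1-cyano-1-methylethyl on a saturated chain carbon, three bonds along the chain from an oxygen on an aromatic ring.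

For the measured compounds named here, no two measured compounds differ from one another in just one place, so there is no measured step that mirrors this change, and the expectation must rest on compound 2 alone. Because compound 2 reaches 85% in this assay, compound 3 is expected to stay in the upper range, with a step from compound 2 to compound 3 of a number 10 percentage points lower from compound 2 to compound 3 (within the scatter), a small move downward that may well remain within the scatter. Compound 3 is therefore estimated to show 75% in this assay, with a plausible range from 50% to 92%.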

Compound 3, a percentage reported as inhibition, at one concentration (the size of the read-out at that concentration, not a potency): 49%
The estimate for compound 3 lay 26 percentage points above the measured number; measured number below the stated range.
By their numbers in this assay, from the lowest: compound 3; then compound 1; then compound 2.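

In this assay, putting (1H-tetrazol-5-yl)methyl in place of 1-cyano-1-methylethyl on a saturated chain carbon, three bonds along the chain from an oxygen on an aromatic ring, gives a number 36 percentage points lower from compound 2 to compound 3 (beyond the scatter). For the compounds shown here, this is the first change in one place seen, and it shows that the read-out is sensitive to what sits at this position, which the earlier pair could not show since those compounds differ in more than one place. Even so, the exchange alters several things at once, replacing an open group that holds a triple bond with a five-membered aromatic ring that carries a hydrogen-bond donor, and no measurement on hand says which of these differences matters for the result.

As far as these compounds go, it remains open whether the lower number goes with the tetrazole ring itself or with the loss of the 1-cyano-1-methylethyl group. A carboxylic acid or a primary amide at the end of the same chain, or a tetrazole on a shorter or a longer chain, would help to separate these possibilities.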